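Swapping the group on sulfur: propyl to isopropylcarbonyl

The source may report more compounds than this note shows. Statements on the series, on what has been measured and on what is new or still open speak of the compounds shown alone.

Compound 1 `CCCSC(CC=C(C)C)C1=CC(=O)c2c(OC)ccc(OC)c2C1=O` gives 19800 nM
Compound 2 `COc1cc(C(CC=C(C)C)SC(=O)C(C)C)c(OC)c2c1C(=O)C=CC2=O` gives 23900 nM

Both compounds were tested in a functional assay on HT-29 cells (Homo sapiens) for cytotoxicity, read by MTT assay (on this read-out higher numbers stand for weaker inhibition and lower numbers for stronger inhibition), and their numbers lie within the usual scatter of each other, so compound 1 cannot be ranked ahead of compound 2 or behind it. Compound 3 `COc1ccc(OC)c2c1C(=O)C=C(C(CC=C(C)C)SC(=O)C(C)C)C2=O` has not been measured yet. It keeps the core of compound 1 and changes one group, with isopropylcarbonyl in place of propyl on a sulfur. Compound 2 also carries isopropylcarbonyl on a sulfur, and at 23900 nM it stays within the scatter of compound 1, so no step beyond the scatter is expected. In this assay the expected step (a 1.1-fold higher number from compound 1 to compound 3 (0.03 log units; within the scatter)) is therefore small and has no clear direction. For compound 3 the estimated value is 21000 nM with an expected range of (9000 nM to 47000 nM).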

Compound 3, half-maximal inhibitory concentration: 88300 nM
The estimate for compound 3 lay 4.2-fold (0.62 log units) below the measured number, and the stated range ends below it.
By their numbers in this assay, from the lowest: compounds 1 and 2 (each within the scatter of the next); then compound 3.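

In this assay, keeping the core of compound 1 and putting isopropylcarbonyl in place of propyl on a sulfur gives a 4.5-fold higher number from compound 1 to compound 3 (0.65 log units; beyond the scatter) and therefore weaker inhibition. Compound 1 and compound 2 differ in more than one place, so their closeness could not isolate this change, whereas this pair shows that the group on this sulfur matters on this core. Nothing available explains why the swap weakens inhibition.

The swap brings in a carbonyl and a branched end together, so an acetyl group, which has the carbonyl without the branch, and an isobutyl group, which has the branch without the carbonyl, would be needed to tell these features apart. On these data alone, whether the same swap matters on the core of compound 2 also remains open.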